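Dithiocarbamates on SK-BR-3 Cells: From Pyrrole to Benzothiophene

A few compounds are considered here, and "the series" means these few. Any claim that something is new, unique, unknown or untested is made for them only; others in the source may bear on it.

Measured so far:
Compound 1, `OCCCSC(=S)NCc1cccnc1`: 1320 nM
Compound 2, `S=C(NCc1cccnc1)SCCc1nnc(-c2cc[nH]c2)o1`: 820 nM

Both compounds were tested in a functional assay on SK-BR-3 cells (Homo sapiens) for cytotoxicity, read by resazurin assay, with a stated time of 72 h; a lower number here means a stronger inhibitor, a higher number a weaker inhibitor. Compound 1 gives 1320 nM in this assay, and compound 2 gives 820 nM. Compound 2 has the lower of the two numbers, but its gap to compound 1 lies within the scatter, so the two cannot be ranked against each other on these data. Compound 3, `S=C(NCc1cccnc1)SCCc1nnc(-c2cc3ccccc3s2)o1`, has not yet been measured. It differs from compound 2 in one place: 1-benzothiophen-2-yl in place of 1H-pyrrol-3-yl on an aromatic carbon. Among the measured compounds shown here, no pair of measured compounds that differ in one place is available, so nothing in the numbers so far points to a direction for this change. The account therefore expects a step from compound 2 to compound 3 of a 1.4-fold lower number from compound 2 to compound 3 (0.14 log units; within the scatter) in this assay, that is, a change not clearly beyond the scatter. For compound 3 the expected value in this assay is 600 nM, with a range from 220 nM to 1600 nM.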

Compound 3, half-maximal inhibitory concentration: 5320 nM
Compound 3: middle estimate off by 8.9-fold (0.95 log units), on the low side; the measured number lies above the stated range.
By their numbers in this assay, from the lowest: compounds 2 and 1 (each within the scatter of the next); then compound 3.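

This is the first step among these compounds that lies beyond the scatter. In this assay, placing 1-benzothiophen-2-yl instead of 1H-pyrrol-3-yl on the aromatic carbon next to the ring nitrogen and next to the ring oxygen gives a 6.5-fold higher number from compound 2 to compound 3 (0.81 log units; beyond the scatter), so the number here does depend on what this position carries. The change adds a six-membered aromatic ring of carbon only, exchanges the ring nitrogen and its hydrogen-bond donor for a ring sulfur, and raises the heavy-atom count from 5 to 9, and nothing available shows which of these matters or why.

The compounds shown leave open whether the higher number follows the added six-membered ring or the ring sulfur. As far as these compounds go, a thiophen-2-yl or a phenyl group at this position would help separate the two, and a pyridinyl group or a carboxylic acid there remains untested in this account.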